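Swapping the Double-Bonded Arm for a Chlorobenzylamino Arm

The source may report more compounds than this note shows. Statements on the series, on what has been measured and on what is new or still open speak of the compounds shown alone.

Compound 1, `CCCCCCCCCCCCCCNC(=O)[C@H](CO)/N=C/c1cccc([N+](=O)[O-])c1`: 104000 nM
Compound 2, `CCCCCCCCCCCCCCNC(=O)[C@H](CO)/N=C/c1ccc(Cl)cc1`: 27500 nM
Compound 3, `CCCCCCCCCCCCCCNC(=O)[C@H](CO)/N=C/c1ccccc1[N+](=O)[O-]`: 21700 nM

All three share the same core and differ only in the aromatic group attached to the carbon with a double bond to nitrogen. In a functional assay on cells (Homo sapiens) for cytotoxicity, read by MTT assay, with a stated time of 24 h (a higher number here means a weaker inhibitor, a lower number a stronger inhibitor), compound 2 gives 27500 nM, the second highest of the three numbers. Its nearest neighbour is compound 3, at a 1.3-fold lower number from compound 2 to compound 3 (0.10 log units; within the scatter), so the two cannot be told apart. Compound 1 lies furthest away, at a 3.8-fold lower number from compound 1 to compound 2 (0.58 log units; beyond the scatter), a step that is clearly beyond the scatter.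

Compound 4, `CCCCCCCCCCCCCCNC(=O)[C@H](CO)NCc1ccccc1Cl`, departs from compound 2 by a change of a different kind: a group of 9 heavy atoms (7 carbon, 1 nitrogen, 1 chlorine; one six-membered aromatic ring of carbon only) in place of a group of 9 heavy atoms (7 carbon, 1 nitrogen, 1 chlorine; one six-membered aromatic ring of carbon only), on a saturated chain carbon bound to a carbonyl carbon and a saturated chain carbon. Here the double bond outside the aromatic rings is gone and a (2-chlorobenzyl)amino group with one hydrogen-bond donor takes its place.

The measured steps bear only loosely on this. a 3.8-fold lower number from compound 1 to compound 2 (0.58 log units; beyond the scatter) and a 4.8-fold lower number from compound 1 to compound 3 (0.68 log units; beyond the scatter) show that moving between aromatic groups can shift the number modestly, while a 1.3-fold lower number from compound 2 to compound 3 (0.10 log units; within the scatter) shows that a chlorine for a nitro group, or a change of ring position, need not. Within the data shown here, no measured step alters the link itself. Compound 4 is therefore expected to give about 25000 nM, within 10000 nM to 60000 nM. The expected step, a 1.1-fold lower number from compound 2 to compound 4 (0.04 log units; within the scatter), is estimated to stay within the usual scatter.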

Compound 4, half-maximal inhibitory concentration: 43700 nM
Compound 4: the middle estimate sits 1.7-fold (0.24 log units) below what was measured; the measured number falls inside the stated range.
By their numbers in this assay, from the lowest: compounds 3, 2 and 4 (each within the scatter of the next); then compound 1.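

The earlier compounds shown here changed only the aromatic group and left the link to the shared core untouched, whereas compound 4 alters the link itself: the double bond outside the aromatic rings is gone and a (2-chlorobenzyl)amino group, with its hydrogen-bond donor, takes its place. In this assay, this gives a 1.6-fold higher number from compound 2 to compound 4 (0.20 log units; within the scatter), so on this saturated chain carbon the double bond is not needed for a number within the scatter of compound 2, although the change also swaps a 4-chlorophenyl for a 2-chlorobenzyl, so the new link and the shifted chlorine cannot be judged separately. No measurement available here explains why the two compounds cannot be told apart.

Still open, from the compounds shown here alone, is whether a 4-chlorobenzylamino group would isolate the effect of the link, and whether a 3-nitrobenzylamino group would carry over the gap that sets compound 1 apart from compound 2 and compound 3. Equally open, going by these compounds, is how the number would respond if a bare amino group stood on this carbon, with no aromatic ring at all.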